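Expected Solubility of an Aminoethoxy Analogue of Compound 2

The source may hold more compounds than are shown below. What is called first, only, known or untested is meant among the compounds shown, and "the series" means these compounds.

Among the three compounds measured in a physicochemical assay for solubility, read by spectrophotometry, using the shake flask method, with a stated time of 2 days, at pH 6.5 (on this read-out lower numbers stand for lower solubility and higher numbers for higher solubility), compound 2 `Oc1ccc(-n2cc(-c3ccc4ccccc4n3)nn2)cc1` stands lowest: in this assay compound 2 gives 2.2 ug/mL. Compound 1 `COCCOc1cccc(Oc2cccc3nc(-c4cn(-c5ccc(O)c(F)c5)nn4)ccc23)c1` gives 6.1 ug/mL in this assay, and compound 3 `O=C(O)CCCOc1ccc2nc(-c3cn(-c4ccc(O)c(F)c4)nn3)ccc2c1` gives 19.2 ug/mL; both of those numbers lie beyond the scatter above the number for compound 2, so compound 2 is the least soluble of the three.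

Compound 4 `NCCOc1ccc2nc(-c3cn(-c4ccc(O)cc4)nn3)ccc2c1` has not yet been measured. It differs from compound 2 in a single place: 2-aminoethoxy in place of hydrogen on an aromatic carbon. Among the compounds with values here, no pair of measured compounds differs in only one place, so there is no measured step to anchor the size of this change; the expectation rests on the spread of the three numbers and on the nature of the group that enters. The step of an 18-fold higher number from compound 2 to compound 4 (1.26 log units; beyond the scatter) is expected to be an increase that lies beyond the scatter. In this assay compound 4 is estimated to give about 40 ug/mL, within a range from 8 ug/mL to 200 ug/mL.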

Compound 4, solubility: 3.7 ug/mL
Compound 4: the middle estimate sits 11-fold (1.03 log units) above what was measured; measured number below the stated range.
By their numbers in this assay, from the lowest: compounds 2, 4 and 1 (each within the scatter of the next, the first and the last beyond it); then compound 3.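

In this assay, within the data shown here, 2-aminoethoxy in place of hydrogen on an aromatic carbon gives a 1.7-fold higher number from compound 2 to compound 4 (0.23 log units; within the scatter), the only measured step at this position. On this six-membered aromatic ring of carbon only, part of a fused system of two rings, a chain of 4 heavy atoms therefore leaves the two compounds within the scatter of each other, and the size of this change now has a measured anchor. Nothing in the data shown offers an explanation for this outcome.

The compounds shown leave open whether a longer chain ending in an amine, or a morpholine ring, at this same place would give a step beyond the scatter. They also leave open whether 2-aminoethoxy would behave alike on another aromatic carbon of the core.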